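Amide aryl swap on the 2,6-dichlorobenzyl analogue

A few compounds are considered here, and "the series" means these few. Any claim that something is new, unique, unknown or untested is made for them only; others in the source may bear on it.

The series shares one core carrying a benzyl group on the ring nitrogen and an aryl amide. Compound 1 `NC(=O)c1c(NC(=O)c2ccc(C(F)(F)F)cc2)sc2c1CCN(Cc1ccccc1F)C2` gives in a functional assay on HL-60 cells (Homo sapiens) for antiproliferative activity, with a stated time of 24 h (a higher number here means a weaker inhibitor, a lower number a stronger inhibitor), only a limit, > 50000 nM. Compound 2 `NC(=O)c1c(NC(=O)c2ccc(C(F)(F)F)cc2)sc2c1CCN(Cc1ccc(Cl)cc1)C2` likewise gives only a limit, > 50000 nM. Among the compounds with values here, compound 3 `NC(=O)c1c(NC(=O)c2ccc(C(F)(F)F)cc2)sc2c1CCN(Cc1c(Cl)cccc1Cl)C2` is the sole member with a read number, 10600 nM, and therefore stands as the only fixed point on the scale. The measured steps, an at least 4.7-fold lower number from compound 1 to compound 3 (0.67 log units; beyond the scatter) and an at least 4.7-fold lower number from compound 2 to compound 3 (0.67 log units; beyond the scatter), both concern the benzyl group; their size is bounded by the limit of > 50000 nM in this assay, at which 2 of the 3 values shown sit, rather than read fully.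

Compound 4 `NC(=O)c1c(NC(=O)c2cccc([N+](=O)[O-])c2)sc2c1CCN(Cc1c(Cl)cccc1Cl)C2` keeps the 2,6-dichlorobenzyl group of compound 3 and changes the amide side: 3-nitrophenyl in place of 4-(trifluoromethyl)phenyl on a carbonyl carbon. Within the data shown here, no measured step touches this position, so none bears directly on it. With compound 3 as the only anchor, the expected step of a 1.1-fold higher number from compound 3 to compound 4 (0.05 log units; within the scatter) is taken as none beyond the scatter. Compound 4 is accordingly estimated at 12000 nM, with a range from 3000 nM to 50000 nM, and a real chance that only a limit is reported.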

Compound 4, half-maximal inhibitory concentration: 18400 nM
The estimate for compound 4 lay 1.5-fold (0.19 log units) below the measured number, and the stated range covers the measured number.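

With the 2,6-dichlorobenzyl group held fixed, the amide side now has a direct reading in this assay: a 1.7-fold higher number from compound 3 to compound 4 (0.24 log units; within the scatter). On this carbonyl carbon, 3-nitrophenyl therefore cannot be told apart from 4-(trifluoromethyl)phenyl, and compound 4 gives the series a second read number on the same benzyl group. No available evidence links this step to a property of either group.

Going by these compounds, whether the amide side behaves the same way with the benzyl groups of compound 1 and compound 2 stays open, and the step between those two compounds cannot be read. Also open, on these data alone, is whether an amine or a carboxylic acid on the amide phenyl ring would move the number beyond the scatter.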